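The source may report more compounds than this note shows. Statements on the series, on what has been measured and on what is new or still open speak of the compounds shown alone.

Measured compounds:
compound 1, `CN(C(=O)CNC(=O)CN)c1ccc([N+](=O)[O-])cc1C(=O)c1ccccc1Cl`: 10 mg/kg
compound 2, `CCC(=O)NCC(=O)N(C)c1ccc(Cl)cc1C(=O)c1ccccc1Cl`: 36 mg/kg

For the measured compounds named here, in a functional assay on the whole organism with Mus musculus as the target, in the rotarod test (a lower number here means that less compound is needed, a higher number that more compound is needed for the effect), compound 2 gives 36 mg/kg, the higher of the two numbers so far, while compound 1 gives 10 mg/kg, a gap that lies beyond the usual scatter of this test. Compound 3, `CN(C(=O)CNC(=O)CN)c1ccc(Cl)cc1C(=O)c1ccccc1Cl`, has not yet been measured in this assay. It keeps the core of compound 2 and differs from it in one place: amino in place of methyl on a saturated chain carbon bound to a carbonyl carbon. Going by the values given here, no step between two measured compounds shows this change on its own, so the expectation for compound 3 rests on its closeness to compound 2 and on the spread of the two numbers that exist. The step from compound 2 to compound 3 is expected to be a 2.0-fold lower number from compound 2 to compound 3 (0.30 log units; within the scatter), towards a lower number and somewhat beyond the scatter. Compound 3 is therefore estimated to give 18 mg/kg in this assay, within a range from 7 mg/kg to 45 mg/kg.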

Compound 3, dose for half-maximal effect: 27.7 mg/kg
Compound 3: the middle estimate sits 1.5-fold (0.19 log units) below what was measured; measured number inside the range.
By their numbers in this assay, from the lowest: compound 1; then compounds 3 and 2 (each within the scatter of the next).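

In this assay, amino in place of methyl on a saturated chain carbon bound to a carbonyl carbon gives a 1.3-fold lower number from compound 2 to compound 3 (0.11 log units; within the scatter) and so stays inside the usual scatter, which means this place on the chain accepts the exchange without a readable shift in these compounds. For the compounds shown here, the exchange of chloro for nitro on an aromatic carbon, with the amino-bearing chain held the same, gives a 2.8-fold higher number from compound 1 to compound 3 (0.44 log units; beyond the scatter) and is the one single-place step here that lies beyond the scatter. Nothing measured here accounts for either step.

Going by these compounds, it remains open whether the chloro and nitro step would hold with the propanoyl chain of compound 2 in place of the amino-bearing chain. Also open, on these data alone, is how a dimethylamino group or a longer chain at the chain end would read, or a nitrile or a bromo group on the aromatic carbon.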